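The source may hold more compounds than are shown below. What is called first, only, known or untested is meant among the compounds shown, and "the series" means these compounds.

Working notes on the series. Compound 1 `COc1ccccc1NC(=S)N/N=C/c1ccc2ccccc2n1` is reported in a functional assay on HT-29 cells (Homo sapiens) for antiproliferative activity, read by sulforhodamine B assay, with a stated time of 72 h (a higher number here means a weaker inhibitor, a lower number a stronger inhibitor), only as a limit, > 100000 nM. Compound 2 `FC(F)(F)c1ccccc1NC(=S)N/N=C/c1ccc2ccccc2n1` gives 18100 nM in this assay, and compound 3 `Cc1ccc(NC(=S)N/N=C/c2ccc3ccccc3n2)cc1` gives 85500 nM. Of the two numbers reported, compound 3 holds the higher one. Changing the group on the aromatic carbon gives an at least 5.5-fold lower number from compound 1 to compound 2 (0.74 log units; beyond the scatter), whereas exchanging the whole aryl gives an at least 1.1-fold lower number from compound 1 to compound 3 (0.06 log units; that floor lies within the scatter), with a floor inside the scatter.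

Compound 4 `Cc1ccccc1NC(=S)N/N=C/c1ccc2ccccc2n1` differs from compound 3 by 2-methylphenyl in place of 4-methylphenyl on an amide-type nitrogen. Compound 1 also carries a 2-methoxyphenyl on that amide-type nitrogen, so both measured steps bear on this change: one is at least modest, the other has a floor inside the scatter, and they run in opposite senses relative to compound 3, so neither fixes a direction for a 2-methylphenyl. A step within the scatter is expected, leaning toward a higher number: a 1.2-fold higher number from compound 3 to compound 4 (0.07 log units; within the scatter). Compound 4 is therefore estimated at 100000 nM, between 30000 nM and 200000 nM, with a fair chance of only a limit.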

Compound 4, half-maximal inhibitory concentration: 42300 nM
For compound 4 the middle estimate is 2.4-fold (0.37 log units) above the measured one, within the range that was stated.
By their numbers in this assay, from the lowest: compound 2; then compound 4; then compound 3. At a limit, above all of these: compound 1.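

In this assay, 2-methylphenyl in place of 4-methylphenyl on the amide-type nitrogen gives a 2.0-fold lower number from compound 3 to compound 4 (0.31 log units; beyond the scatter), so with the same atoms, the place of the methyl alone moves the number beyond the scatter. On the same aromatic carbon, methyl in place of trifluoromethyl gives a 2.3-fold higher number from compound 2 to compound 4 (0.37 log units; beyond the scatter), which sets methyl apart from trifluoromethyl. Methyl in place of methoxy gives an at least 2.3-fold lower number from compound 1 to compound 4 (0.37 log units; beyond the scatter), and that step is only a floor, as compound 1 is reported only as a limit: the limit of > 100000 nM in this assay, at which 1 of the 4 values shown sits.

Open, going by these compounds, is whether the place of the group counts in the same way for trifluoromethyl or methoxy as it does for methyl. Also open, on these data alone, is whether a chlorine, an ethyl or an amine on that aromatic carbon would fall within the order seen so far.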